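The source may report more compounds than this note shows. Statements on the series, on what has been measured and on what is new or still open speak of the compounds shown alone.

In a functional assay on HCT-116 cells (Homo sapiens) for antiproliferative activity, read by MTT assay, with a stated time of 72 h (a higher number here means a weaker inhibitor of growth, a lower number a stronger inhibitor of growth), the measured compounds read as follows:
- compound 1 `COc1cc(OC)c(/C=C/S(=O)(=O)Cc2cnc(Cl)cn2)c(OC)c1`: > 10000 nM, a limit of the assay
- compound 2 `CCOc1cnc(CS(=O)(=O)/C=C/c2c(OC)cc(OC)cc2OC)cn1`: 1280 nM
- compound 3 `COc1cc(OC)c(/C=C/S(=O)(=O)Cc2nc(Cl)ncc2OC)c(OC)c1`: > 10000 nM, a limit of the assay

Compound 3 gives no number and sits at the limit of > 10000 nM in this assay, at which 2 of the 3 values shown sit. Compound 4 `CNc1ncc(OC)c(CS(=O)(=O)/C=C/c2c(OC)cc(OC)cc2OC)n1` differs from it by one change: methylamino in place of chloro on an aromatic carbon. This is methylamino in place of chloro on an aromatic carbon, between two ring nitrogen atoms.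

The closest measured precedent is an at least 7.8-fold lower number from compound 1 to compound 2 (0.89 log units; beyond the scatter), where ethoxy took the place of chloro on an aromatic carbon. That step lies beyond the scatter, but it was made on a different ring and with a different incoming group. The step of an at least 7.8-fold higher number from compound 2 to compound 3 (0.89 log units; beyond the scatter) is also beyond the scatter, though it changes the whole ring and its substituents at once. The step that the two limits leave unreadable from compound 1 to compound 3 cannot be read, as both ends are limits. Among these three compounds, only the one without chloro gives a number.

A modest move towards a lower number is therefore expected in this assay, although a result that stays at the limit remains possible. The expected change is an at least 4.0-fold lower number from compound 3 to compound 4 (0.60 log units; beyond the scatter). The estimated value for compound 4 is 2500 nM. The expected range for compound 4 runs from 600 nM to 10000 nM.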

Compound 4, concentration for 50% growth inhibition: > 10000 nM
Compound 4 was reported as a limit (the forecaster's own chance of this, stated with the estimate: 25%); middle value at least 4.0-fold (0.60 log units) from the limit.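

In this assay compound 4 gives > 10000 nM, a limit of the assay. Compound 3 also stands at a limit, so the step from compound 3 to compound 4 cannot be read, and this result joins the others at that ceiling: the limit of > 10000 nM in this assay, at which 3 of the 4 values shown sit. The compounds shown leave open whether methylamino in place of chloro changes growth inhibition at all.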